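Swapping the pyridine for chlorophenyl in an HDAC6 hydroxamate series

The source may hold more compounds than are shown below. What is called first, only, known or untested is meant among the compounds shown, and "the series" means these compounds.

Of the compounds shown here, three share one core and have been measured. Compound 1 `O=C(NO)c1ccc(NCc2nc(-c3ccco3)nn2-c2ccccc2)cc1` gives 59.9% in an assay on Sf9 cells for inhibition of protein deacetylase HDAC6 (Homo sapiens), read by fluorescence, with a stated time of 40 min, tested at 100 nM; a lower number here means less inhibition, a higher number more inhibition at the concentration tested (going by the name of the read-out). Compound 2 `O=C(NO)c1ccc(NCc2nc(-c3ccccc3Cl)nn2-c2ccccc2)cc1` gives 75%. Compound 3 `O=C(NO)c1ccc(NCc2nc(-c3ccncc3)nn2-c2ccccc2)cc1` gives 30.8%.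

On these numbers compound 3 stands lowest of the three: the change from a furan-2-yl group to a pyridin-4-yl group brought a number 29.1 percentage points lower from compound 1 to compound 3 (beyond the scatter), and the change from a 2-chlorophenyl group to a pyridin-4-yl group brought a number 44.2 percentage points lower from compound 2 to compound 3 (beyond the scatter), a large drop. Compound 2 sits highest, with a number 15.1 percentage points higher from compound 1 to compound 2 (beyond the scatter) separating it from compound 1.

Compound 4 `O=C(NO)c1ccc(NCc2nc(-c3cccc(Cl)c3)nn2-c2ccccc2)cc1` has not yet been measured. It differs from compound 3 in one place: 3-chlorophenyl in place of pyridin-4-yl on an aromatic carbon.

The step that bears most on this change is the large one from compound 2 to compound 3, since compound 4 again carries a chlorophenyl group in place of the pyridin-4-yl group, only with the chlorine at a different spot of the ring. The modest step between compound 1 and compound 2 also points the same way. A large rise is therefore expected for compound 4, back toward the level of compound 2. Compound 4 is estimated at 70%, with a range from 52% to 85%, which means an expected step of a number 39.2 percentage points higher from compound 3 to compound 4 (beyond the scatter).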

Compound 4, a percentage reported as inhibition, at one concentration (the size of the read-out at that concentration, not a potency): 61.2%
Compound 4: middle estimate off by 8.8 percentage points, on the high side; low and high end bracket the measured number.
By their numbers in this assay, from the lowest: compound 3; then compounds 1 and 4 (each within the scatter of the next); then compound 2.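

The rise of a number 30.4 percentage points higher from compound 3 to compound 4 (beyond the scatter) shows that the gain over pyridin-4-yl at this position is not confined to the 2-chlorophenyl group, since a second chlorophenyl group also gives a higher number than the pyridine. Where the chlorine sits on that ring still counts, as the change from 2-chlorophenyl to 3-chlorophenyl gives a number 13.8 percentage points lower from compound 2 to compound 4 (beyond the scatter) and so does not fully preserve the level of compound 2. The 3-chlorophenyl and furan-2-yl groups cannot be told apart in this assay, with a number 1.3 percentage points higher from compound 1 to compound 4 (within the scatter) and no available measurement accounts for any of these steps.

The compounds shown leave open whether the chlorine is needed at all, which a plain phenyl group would test, and whether a 4-chlorophenyl group would follow compound 2 or compound 4. They also leave open whether a methoxy group or a methyl group in place of the chlorine would keep these numbers, and all of these readings come from a single concentration rather than from a full potency measurement.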